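A small fragment gains three carbons on its sulfur chain

The compounds below may be only part of what the source reports. "The series", "measured", "known", "first", "only" and "open" are said of these compounds alone.

The series shares a small core, seen most plainly in compound 3 `CSC(=S)N[C@H]1CCOC1=O`. Two larger relatives carry an aryl amide on the same core: compound 1 `O=C(CSC(=S)N[C@H]1CCOC1=O)Nc1ccc(Cl)cc1` and compound 2 `O=C(CSC(=S)N[C@H]1CCOC1=O)Nc1ccc(F)cc1`. In a functional assay on MCF7 cells (Homo sapiens) for cytotoxicity, read by MTT assay, with a stated time of 72 h (a lower number here means a stronger inhibitor, a higher number a weaker inhibitor), compound 1 gives 50300 nM. Compound 2 gives 5830 nM, which is an 8.6-fold lower number from compound 1 to compound 2 (0.94 log units; beyond the scatter).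

Compound 3 stands apart from these two, at the top of the numbers rather than among them. Its result is a limit of the assay, not a number: in this assay compound 3 gives > 128000 nM, and (the limit of > 128000 nM in this assay, at which 1 of the 3 values shown sits).

Compound 4 `CCCCSC(=S)N[C@H]1CCOC1=O` differs from compound 3 by propyl in place of hydrogen on a saturated chain carbon bound to a sulfur, the difference that, cut one bond further out, reads methyl to butyl. Among the compounds with values here, the only measured step, the halogen swap from compound 1 to compound 2, concerns a different part of the molecule and tells nothing direct about lengthening this chain. With compound 3 already at the limit, compound 4 is expected to sit near that limit too, so the step that the limit leaves unreadable from compound 3 to compound 4 is estimated to be small or absent. For compound 4 the expected value is 150000 nM, within a range from 40000 nM to 500000 nM.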

Compound 4, half-maximal inhibitory concentration: > 128000 nM
Compound 4: only a limit was reported; the forecaster's own chance of this, stated with the estimate: 65%; the middle value is on the limit's open side.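

In this assay, compound 3 and compound 4 both rest at a limit of the assay rather than at a number, so no step between them can be read: the limit of > 128000 nM in this assay, at which 2 of the 4 values shown sit.

The compounds shown leave open whether going from methyl to butyl on this sulfur chain changes the cytotoxicity at all.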